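Replacing the pyrrole of compound 2 with a trifluoromethylphenyl arylidene

A few compounds are considered here, and "the series" means these few. Any claim that something is new, unique, unknown or untested is made for them only; others in the source may bear on it.

The shared core, a nucleoside bearing a hydrazone arm, is kept in every compound here; only the aryl group at the end of that arm changes. Compound 2 `Nc1nc(N/N=C/c2ccc[nH]2)nc2c1ncn2[C@@H]1O[C@H](CO)[C@@H](O)[C@H]1O` carries a 1H-pyrrol-2-yl group and, in an assay on CHO-K1 cells for displacement of a labelled ligand from adenosine receptor A1 (Homo sapiens), read by scintillation counting, with a stated time of 60 min (a lower number here means a stronger inhibitor, a higher number a weaker inhibitor), compound 2 gives 8 nM. Among the three measured compounds, compound 2 stands second highest: compound 1 `Nc1nc(N/N=C/c2ccc(N3CCCC3)cc2)nc2c1ncn2[C@@H]1O[C@H](CO)[C@@H](O)[C@H]1O` gives 5.1 nM, and the step of a 1.6-fold higher number from compound 1 to compound 2 (0.20 log units; within the scatter) is within the scatter, so the two cannot be ordered. Compound 3 `Nc1nc(N/N=C/c2ccc(OCc3ccc(F)cc3)cc2)nc2c1ncn2[C@@H]1O[C@H](CO)[C@@H](O)[C@H]1O` gives 70 nM, and the step of a 14-fold higher number from compound 1 to compound 3 (1.14 log units; beyond the scatter) shows that changing the group on the phenyl ring can cost a great deal.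

Compound 4 `Nc1nc(N/N=C/c2ccc(C(F)(F)F)cc2)nc2c1ncn2[C@@H]1O[C@H](CO)[C@@H](O)[C@H]1O` is the next compound, not yet measured. The change from compound 2 is 4-(trifluoromethyl)phenyl in place of 1H-pyrrol-2-yl on a carbon with a double bond to nitrogen. For the measured compounds named here, two measured steps bear on it. The step from compound 1 to compound 2 shows that swapping a pyrrolyl for a substituted phenyl need not move the number, while the step from compound 1 to compound 3 shows that the identity of the phenyl substituent can raise it markedly. The trifluoromethyl substituent resembles neither the pyrrolidinyl of compound 1 nor the fluorobenzyloxy of compound 3, so a modest rise is expected for compound 4, a 2.5-fold higher number from compound 2 to compound 4 (0.40 log units; beyond the scatter). Compound 4 is therefore estimated at 20 nM, within 6 nM to 70 nM.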

Compound 4, inhibition constant: 37 nM
Estimate against measurement, compound 4: 1.9-fold (0.27 log units) below; low and high end bracket the measured number.
By their numbers in this assay, from the lowest: compounds 1 and 2 (each within the scatter of the next); then compounds 4 and 3 (each within the scatter of the next).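

In this assay, the step from the 1H-pyrrol-2-yl group to 4-(trifluoromethyl)phenyl on the carbon with a double bond to nitrogen is not neutral (a 4.6-fold higher number from compound 2 to compound 4 (0.67 log units; beyond the scatter)), so the level seen for the pyrrole and for compound 1 does not carry over to every phenyl arm. Trifluoromethyl in place of pyrrolidin-1-yl on an aromatic carbon also raises the number (a 7.3-fold higher number from compound 1 to compound 4 (0.86 log units; beyond the scatter)), which makes this the second substituent, after (4-fluorobenzyl)oxy, to lose ground against pyrrolidin-1-yl. The rise is therefore not confined to (4-fluorobenzyl)oxy, and the two substituents cannot be ordered against each other (a 1.9-fold lower number from compound 3 to compound 4 (0.28 log units; within the scatter)), leaving compound 1 as the only one of the three phenyl compounds that stays level with the pyrrole.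

On these data alone, whether that level depends on pyrrolidin-1-yl itself or would also hold with another amine, such as a dimethylamino group, or with a carboxylic acid or a longer alkyl chain on that aromatic carbon remains open. No evidence is available here that accounts for any of these steps.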